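Replacing 4-Bromophenyl with 2-Hydroxyphenyl: An Expected Dose

The source may hold more compounds than are shown below. What is called first, only, known or untested is meant among the compounds shown, and "the series" means these compounds.

Compound 1 `O=C(N/N=C/c1ccc(F)cc1)Nc1cccc2ccccc12`: 300 mg/kg
Compound 2 `O=C(N/N=C/c1ccc(Br)cc1)Nc1cccc2ccccc12`: 300 mg/kg

In a functional assay on the whole organism (strain Swiss albino) with Mus musculus as the target, with a stated time of 0.5 h (on this read-out higher numbers stand for an effect only at larger amounts of compound and lower numbers for an effect already at smaller amounts), compound 1 gives 300 mg/kg, and compound 2 gives 300 mg/kg. Within the data shown here, the one measured step, no change at the digits printed from compound 1 to compound 2 (within the scatter), shows no movement, so compound 2 stands level with compound 1. Compound 3 `O=C(N/N=C/c1ccccc1O)Nc1cccc2ccccc12` carries a different group on the same carbon: 2-hydroxyphenyl in place of 4-bromophenyl on a carbon with a double bond to nitrogen. The measured step swaps one halogen for another and bears only loosely on an exchange for a hydroxyl-bearing ring; nothing measured here tests such a change. The step is therefore expected to stay within the scatter, no change at the digits printed from compound 2 to compound 3 (within the scatter). Compound 3 is estimated at 300 mg/kg, expected between 100 mg/kg and 600 mg/kg.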

Compound 3, minimum effective dose: 300 mg/kg
For compound 3 middle estimate and measured number coincide at the digits printed; low and high end bracket the measured number.
By their numbers in this assay, from the lowest: compounds 1, 2 and 3 (each within the scatter of the next).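

Up to this point, only one halogen had been swapped for another at this place. The new result extends the picture to a ring with a hydroxyl: 2-hydroxyphenyl has hydrogen-bond donors and acceptors, which 4-bromophenyl lacks, yet this assay shows no change at the digits printed from compound 2 to compound 3 (within the scatter). The comparison with the fluorine-bearing compound reads the same, no change at the digits printed from compound 1 to compound 3 (within the scatter). Nothing available explains this lack of movement. Still open, from the compounds shown here alone, is whether an amine or a carboxylic acid on this ring, or a longer chain in its place, would shift the minimum effective dose.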